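The source may report more compounds than this note shows. Statements on the series, on what has been measured and on what is new or still open speak of the compounds shown alone.

The three compounds measured in a physicochemical assay, read by spectrophotometry, with a stated time of 6 min; a lower number here means a stronger inhibitor, a higher number a weaker inhibitor:
compound 1, `O=C(CCc1nc2ccccc2c(=O)[nH]1)N/N=C/c1ccc(Cl)cc1`, gives 185000000 nM;
compound 2, `COc1ccc(/C=N/NC(=O)CCc2nc3ccccc3c(=O)[nH]2)cc1`, gives 75000000 nM;
compound 3, `COc1cc(/C=N/NC(=O)CCc2nc3ccccc3c(=O)[nH]2)ccc1O`, gives 95000000 nM.

Compound 3 stands second highest of the three numbers. Its nearest neighbour is compound 2, and the gap between them, a 1.3-fold higher number from compound 2 to compound 3 (0.10 log units; within the scatter), is within the scatter; the gap to compound 1, a 1.9-fold lower number from compound 1 to compound 3 (0.29 log units; within the scatter), is also within the scatter. For the measured compounds named here, only the step of a 2.5-fold lower number from compound 1 to compound 2 (0.39 log units; beyond the scatter) reaches beyond it, and that step is modest.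

Compound 4, `COc1cc(/C=N/NC(=O)CCc2nc3ccccc3c(=O)[nH]2)cc(O)c1O`, has not been measured. It differs from compound 3 in one place: hydroxy in place of hydrogen on an aromatic carbon. Going by the values given here, no measured pair shows exactly a hydroxy put in place of hydrogen. The closest guide is the step of a 1.3-fold higher number from compound 2 to compound 3 (0.10 log units; within the scatter), where a hydroxy arrives as part of a larger exchange and the two numbers lie within the scatter of each other. The other two steps, a 1.9-fold lower number from compound 1 to compound 3 (0.29 log units; within the scatter) and a 2.5-fold lower number from compound 1 to compound 2 (0.39 log units; beyond the scatter), concern a chloro leaving and do not bear directly on this change. No step beyond the scatter is therefore expected in this assay, and if anything a slightly lower number. Compound 4 is estimated at 70000000 nM, between 35000000 nM and 140000000 nM, which would mean a step of a 1.4-fold lower number from compound 3 to compound 4 (0.13 log units; within the scatter).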

Compound 4, half-maximal inhibitory concentration: 40000000 nM
Compound 4: middle estimate off by 1.8-fold (0.24 log units), on the high side; the range from low to high includes it.
By their numbers in this assay, from the lowest: compounds 4, 2, 3 and 1 (each within the scatter of the next, the first and the last beyond it).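

In this assay, a hydroxy placed on an aromatic carbon, ortho to a hydroxy group and meta to a methoxy group, gives a 2.4-fold lower number from compound 3 to compound 4 (0.38 log units; beyond the scatter), a modest step towards a stronger inhibitor and the first step shown that comes from this one added group alone. The earlier step that brought in a hydroxy, a 1.3-fold higher number from compound 2 to compound 3 (0.10 log units; within the scatter), did so as part of a larger exchange of the whole substituted phenyl group, so it could not show what a single hydroxy does on this carbon. Nothing shown here gives a reason for the lower number.

The compounds shown leave open whether the hydroxy itself matters or whether another small group on this same carbon, such as a methoxy, an amine or a fluoro, would shift the number in the same way. They also leave open whether this hydroxy would give a similar step without the hydroxy group ortho to it, and whether it would hold with a longer chain joining the shared core to the carbonyl.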